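The source may report more compounds than this note shows. Statements on the series, on what has been measured and on what is new or still open speak of the compounds shown alone.

Measured compounds:
- compound 1 `CCOC(=O)CC(=O)CSc1nnc(COc2ccccc2C2=NOC(c3ccc(Cl)cc3Cl)C2)n1NC(=O)CCl`; in an ADME assay (MDM cells, Homo sapiens) for cytotoxicity, read by resazurin assay, with a stated time of 3 days (a lower number here means a stronger inhibitor, a higher number a weaker inhibitor), compound 1 gives "not determined" (no result reported)
- compound 2 `CCOC(=O)CC(=O)CSc1nnc(COc2ccccc2C2=NOC(c3ccc(Cl)cc3Cl)C2)n1NC(C)=O`; in this assay compound 2 gives "not determined" (no result reported)
- compound 3 `CC(=O)Nn1c(S)nnc1COc1ccccc1C1=NOC(c2ccc(Cl)cc2Cl)C1`; in this assay compound 3 gives 1.3 ug/mL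

Compound 1 stands without a number in this assay: no result was reported for it, and the same holds for compound 2. The only measured value among these three compounds belongs to compound 3, which in this assay gives 1.3 ug/mL. Compound 3 shares the larger part of its structure with compound 1 but carries a thiol where compound 1 carries a longer sulfur-linked chain, and an acetyl group where compound 1 carries a chloroacetyl group.

Compound 4 `CSc1nnc(COc2ccccc2C2=NOC(c3ccc(Cl)cc3Cl)C2)n1NC(=O)CCl` is the next compound to be tested. It differs from compound 1 in one place: hydrogen in place of ((ethoxycarbonyl)methyl)carbonyl on a saturated chain carbon bound to a sulfur. The sulfur-linked chain is thus shortened to a single carbon, while the rest of compound 1 is kept.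

Among the compounds with values here, no measured step between two compounds is available, so the size of this change in this assay cannot be read from a comparable pair. The expectation is therefore drawn from compound 3 alone, whose value in this assay is 1.3 ug/mL, with a wide allowance for the parts in which compound 4 differs from compound 3. For compound 4 in this assay the expected value is 2 ug/mL, estimated to fall between 0.5 ug/mL and 8 ug/mL.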

Compound 4, half-maximal inhibitory concentration: 2.7 ug/mL
The estimate for compound 4 lay 1.4-fold (0.13 log units) below the measured number, within the range that was stated.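

In this assay compound 4 gives 2.7 ug/mL but compound 1 has no single number, and compound 3 differs from compound 4 in more than one place, so no step can be read. The compounds shown leave open how much the ((ethoxycarbonyl)methyl)carbonyl group contributes to this read-out. Nothing shown here offers an explanation for the value of compound 4.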